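This account rests on a few compounds, and the source may have more. Where it says the series, first, only, none or still open, it means among the compounds named here.

Compound 1 `CCCc1nc(-c2ccccc2)c(CNCCN2CCN(c3ccc(C(F)(F)F)cc3)CC2)o1` gives 1300 nM in an assay on HEK293 cells for inhibition of Voltage-dependent T-type calcium channel subunit alpha-1G (Homo sapiens), read by patch clamp; on this read-out lower numbers stand for stronger inhibition and higher numbers for weaker inhibition. Compound 2 `CCCc1nc(-c2ccccc2)c(CNCCN2CCN(c3ccccc3C)CC2)o1` gives 4300 nM.

Among these two numbers compound 2 stands highest; the one measured step between them is a 3.3-fold higher number from compound 1 to compound 2 (0.52 log units; beyond the scatter), a modest shift. Compound 3 `CCCc1nc(-c2ccccc2)c(CNCCN2CCN(c3cccc(Cl)c3)CC2)o1` differs from compound 2 by 3-chlorophenyl in place of 2-methylphenyl on an amine nitrogen in a ring. The step from compound 1 to compound 2 is the only one that bears on an exchange at this ring nitrogen, so a change of similar size is expected, this time lowering the number by a 2.2-fold lower number from compound 2 to compound 3 (0.33 log units; beyond the scatter). Compound 3 is therefore estimated at 2000 nM, with a range from 700 nM to 6000 nM.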

Compound 3, half-maximal inhibitory concentration: 1450 nM
Compound 3: middle estimate off by 1.4-fold (0.14 log units), on the high side; the range from low to high includes it.
By their numbers in this assay, from the lowest: compounds 1 and 3 (each within the scatter of the next); then compound 2.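

Exchanging 2-methylphenyl for 3-chlorophenyl on the ring nitrogen moves the number down (a 3.0-fold lower number from compound 2 to compound 3 (0.47 log units; beyond the scatter)), so this position responds to the aryl group in both directions. Two differently substituted phenyl groups give matching results (a 1.1-fold higher number from compound 1 to compound 3 (0.05 log units; within the scatter)), which leaves compound 2 alone apart from compound 1 and compound 3. Nothing available explains these shifts.

Each exchange alters both the substituent and where it sits on the phenyl ring, so the two effects stay tangled. Going by these compounds, how an unsubstituted phenyl, 2-chlorophenyl, 4-chlorophenyl or a pyridyl group would behave here remains open.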